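A few compounds are considered here, and "the series" means these few. Any claim that something is new, unique, unknown or untested is made for them only; others in the source may bear on it.

Three small fused bicyclic heteroaromatics have so far been tested in a functional assay for inhibition, with Homo sapiens as the target; a higher number here means a weaker inhibitor, a lower number a stronger inhibitor. Compound 1 `CNc1nncc2cncn12` carries a methylamino group on the shared core; in this assay compound 1 reaches only a limit of the assay, > 48000 nM. Compound 2 `CC(C)c1ncn2c(S)nncc12` bears an isopropyl group together with a sulfanyl group; in this assay compound 2 likewise gives only a limit, > 48000 nM. Compound 3 `Cc1nnc(S)n2cncc12` combines a methyl group with a sulfanyl group on the same core; in this assay compound 3 again returns only a limit, > 48000 nM. Compound 3 therefore cannot be placed above or below its two companions: every value recorded so far sits at the limit described by the limit of > 48000 nM in this assay, at which 3 of the 3 values shown sit, and none of them is a number.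

The step to compound 4 `Sc1nncc2cncn12` is hydrogen in place of methyl on an aromatic carbon. Among the measured compounds shown here, no measured pair in this set differs in one place, so the size of such a change is not known from these data. With all three earlier compounds at the limit, the expected step from compound 3 to compound 4 is a step that the limit leaves unreadable from compound 3 to compound 4, none beyond the scatter. Compound 4 is accordingly expected to give 100000 nM in this assay, within a range from 30000 nM to 500000 nM, most probably as another limit.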

Compound 4, half-maximal inhibitory concentration: > 48000 nM
Compound 4: a limit, no number (the forecaster's own chance of this, stated with the estimate: 85%); the middle value lies beyond the limit too.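

Like compound 1, compound 2 and compound 3, compound 4 ends at a limit rather than a number in this assay, so none of its steps to those three compounds can be read: the limit of > 48000 nM in this assay, at which 4 of the 4 values shown sit.

The compounds shown leave open how large any of these replacements on the shared core is, and whether any substituent there gives a numerical value in this assay.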